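This account rests on a few compounds, and the source may have more. Where it says the series, first, only, none or still open, it means among the compounds named here.

Measured so far:
compound 1, `O=C(CCCCOc1cccc(-c2nnc(-c3ccccc3)s2)c1)NO`, gives 32 nM
compound 2, `O=C(CCCCCOc1cccc(-c2nnc(-c3ccccc3)s2)c1)NO`, gives 20 nM
compound 3, `O=C(CCCCCCOc1cccc(-c2nnc(-c3ccccc3)s2)c1)NO`, gives 185 nM

In an assay on HeLa cells for inhibition of protein deacetylase HDAC6 (Homo sapiens), read by fluorescence, with a stated time of 30 min (on this read-out higher numbers stand for weaker inhibition and lower numbers for stronger inhibition), compound 3 gives the highest of the three numbers; the steps of a 5.8-fold higher number from compound 1 to compound 3 (0.76 log units; beyond the scatter) and a 9.3-fold higher number from compound 2 to compound 3 (0.97 log units; beyond the scatter) both lie beyond the scatter, so compound 3 is the weakest inhibitor of the set. Compound 4, `O=C(CCCCCCOc1cccc(-c2nnc(-c3ccccc3Cl)s2)c1)NO`, differs from compound 3 by chloro in place of hydrogen on an aromatic carbon. Among the compounds with values here, every measured step concerns only the length of the chain that carries the hydroxycarbamoyl group; none touches the phenyl ring, so no measured step bears on this change. With nothing to point in either direction, the expected step is no change at the digits printed from compound 3 to compound 4 (within the scatter), nothing beyond the scatter. Compound 4 is estimated at 185 nM, within 60 nM to 550 nM.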

Compound 4, half-maximal inhibitory concentration: 30 nM
For compound 4 the middle estimate is 6.2-fold (0.79 log units) above the measured one; measured number outside the range, below it.
By their numbers in this assay, from the lowest: compounds 2, 4 and 1 (each within the scatter of the next); then compound 3.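

Within the data shown here, changing phenyl to 2-chlorophenyl gives a 6.2-fold lower number from compound 3 to compound 4 (0.79 log units; beyond the scatter) in this assay, so the outer ring, unchanged in the earlier compounds, also matters here, and chain length is not the only place that moves the number. This single chloro group, ortho to a large group, is enough for a step beyond the scatter. No measurement here accounts for the step. Going by these compounds, it remains open whether a fluoro or methoxy group in the same place would act like chloro, and whether chloro would give a similar step on the shorter chains of compound 1 and compound 2.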